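A few compounds are considered here, and "the series" means these few. Any claim that something is new, unique, unknown or untested is made for them only; others in the source may bear on it.

In a toxicity assay (Homo sapiens) for cytotoxicity (a lower number here means that less compound is needed, a higher number that more compound is needed for the effect), compound 1 `Nc1nc(F)nc2c1ncn2[C@@H]1O[C@H](CO)C=C1F` gives > 100000 nM, which is a limit of the assay and not a number. Compound 2 `Nc1nc(Cl)c2ncn([C@@H]3O[C@H](CO)C=C3F)c2n1` gives 77400 nM; 98800 nM (2 entries), so it has actual readings. Compound 3 `Nc1nc(F)nc2c1ncn2[C@H]1O[C@H](CO)C=C1F` has the same atoms and bonds as compound 1 and differs only in configuration as drawn: the two compounds have the same atoms and bonds and differ only in configuration as drawn: 1 of 2 stereo elements differ; a stereocentre at a saturated ring carbon is drawn R in compound 1 and S in compound 3. A stereocentre at a saturated ring carbon is drawn R in compound 1 and S in compound 3. Going by the values given here, no measured pair shows what such a change does in this assay, so no shift beyond the scatter is expected, in either direction. Among the compounds with values here, the one measured reference is compound 2 at 77400 nM; 98800 nM (2 entries), and compound 3 is expected to stay in that same high range. The expected change is a number no higher from compound 1 to compound 3 (the limit leaves the size open). For compound 3 the estimated value is 100000 nM, with an expected range from 40000 nM to 200000 nM.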

Compound 3, half-maximal effective concentration: 41200 nM
The estimate for compound 3 lay 2.4-fold (0.39 log units) above the measured number; low and high end bracket the measured number.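

Turning one stereocentre at a saturated ring carbon from R to S gives, in this assay, an at least 2.4-fold lower number from compound 1 to compound 3 (0.38 log units; beyond the scatter), the first change in this set that can be read as a single step. From the compounds shown here alone, compound 1 gives > 100000 nM, which is a limit and not a number, so the step has a lower bound and its full size stays open. With atoms and bonds unchanged, the shift can be put down to configuration alone: the fact that compounds 1 and 3 differ only in the configuration as drawn.

The compounds shown do not tell whether the same inversion would shift the number in the same direction on a compound that has a measured value at both configurations, or whether the other stereo element matters as well. They also leave open what a carboxylic acid or a longer chain on the shared core would do in this assay.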